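Extending the ethyl chain of compound 3 to butyl

The source may report more compounds than this note shows. Statements on the series, on what has been measured and on what is new or still open speak of the compounds shown alone.

compound 1 `COCc1cc(=O)c(O)co1` gives -0.62
compound 2 `CCOCc1cc(=O)c(O)co1` gives -0.38
compound 3 `CCc1oc(C)cc(=O)c1O` gives 1.07

In an ADME assay for lipophilicity (on this read-out higher numbers stand for higher lipophilicity and lower numbers for lower lipophilicity), compound 3 has the highest of the three numbers. Its gaps to compound 2, the nearest, and to compound 1, the furthest, both lie beyond the usual scatter of repeated measurements.

The next structure, compound 4 `CCCCc1oc(C)cc(=O)c1O`, has not yet been measured. Its difference from compound 3 is ethyl in place of hydrogen on a saturated chain carbon, two bonds along the chain from an aromatic carbon in other words ethyl in place of hydrogen on a saturated chain carbon, two bonds along the chain from an aromatic carbon. The same change can be read as ethyl to butyl.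

Within the data shown here, only one measured step bears on this. It is a number 0.24 log units higher from compound 1 to compound 2 (within the scatter) for methyl in place of hydrogen on a saturated chain carbon bound to an oxygen on a saturated carbon. This is a thin guide, as it involves a smaller group in a different place, and no change to compound 3 itself has been measured. Ethyl is the larger group, so a larger step in the same direction is expected. The estimate is a number 0.83 log units higher from compound 3 to compound 4 (beyond the scatter) and so is expected to lie beyond the scatter. Compound 4 is expected to read 1.9 (estimated range 1.4 to 2.4).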

Compound 4, distribution coefficient: 1.92
Compound 4: middle estimate off by 0.02 log units, on the low side; measured number inside the range.
By their numbers in this assay, from the lowest: compounds 1 and 2 (each within the scatter of the next); then compound 3; then compound 4.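

In this assay, among these compounds, the change from ethyl to butyl gives a number 0.85 log units higher from compound 3 to compound 4 (beyond the scatter) and so provides the first direct reading on this saturated chain carbon, two bonds along the chain from an aromatic carbon. Among the compounds shown here, the only earlier step, a number 0.24 log units higher from compound 1 to compound 2 (within the scatter) for a methyl group, sits on a different compound and at a different place, so the two steps differ in more than the size of the added group and cannot show how much of the contrast comes from size alone. Nothing measured in this set gives a reason for the size of the step from ethyl to butyl.

As far as these compounds go, whether a longer chain such as hexyl would carry the number further in the same direction remains open, as does the outcome for a branched chain such as isopropyl or a butyl chain ending in an amine or a carboxylic acid. Also open, from the compounds shown here alone, is whether the same ethyl group would give a step of similar size at another place on the shared core, since a single step at a single position cannot settle how far it carries over.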